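Pyrazolyl-furan amides: amide replaces sulfonamide on side chain

The source may hold more compounds than are shown below. What is called first, only, known or untested is meant among the compounds shown, and "the series" means these compounds.

Measured in an assay for inhibition of RAC-alpha serine/threonine-protein kinase (Homo sapiens), read by HTRF, with a stated time of 1 h; a lower number here means a stronger inhibitor, a higher number a weaker inhibitor:
compound 1 `Cn1ncc(Cl)c1-c1cc(C(=O)N[C@@H]2CN[C@H](CCNS(C)(=O)=O)C[C@H]2c2ccc(F)c(F)c2)oc1Cl` 3.29 nM
compound 2 `Cn1ncc(Cl)c1-c1cc(C(=O)N[C@@H]2CN[C@H](CCN3CCCCC3)C[C@H]2c2ccc(Cl)c(Cl)c2)oc1Cl` 5.65 nM
compound 3 `Cn1ncc(Cl)c1-c1cc(C(=O)N[C@@H]2CN[C@H](CC(N)=O)C[C@H]2c2ccc(Cl)c(Cl)c2)oc1Cl` 3.24 nM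

Compound 1 sits with compounds 2 and 3 inside the usual scatter of this assay; no gap among the three exceeds it. Compound 4 `CNC(=O)C[C@@H]1C[C@@H](c2ccc(F)c(F)c2)[C@H](NC(=O)c2cc(-c3c(Cl)cnn3C)c(Cl)o2)CN1` carries methylcarbamoyl in place of (methanesulfonamido)methyl on a saturated chain carbon bound to a saturated ring carbon. Going by the values given here, the only related step measured, a 1.7-fold lower number from compound 2 to compound 3 (0.24 log units; within the scatter), exchanged one side-chain end for an amide and stayed within the scatter. Among the compounds with values here, that step is the sole guide, so for compound 4 no move beyond the scatter is expected: the step from compound 1 to compound 4 is estimated as a 1.1-fold higher number from compound 1 to compound 4 (0.03 log units; within the scatter). Compound 4 is therefore expected to give 3.5 nM in this assay, with a likely range from 1.5 nM to 8 nM.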

Compound 4, half-maximal inhibitory concentration: 1.37 nM
Estimate against measurement, compound 4: 2.6-fold (0.41 log units) above; measured number outside the range, below it.
By their numbers in this assay, from the lowest: compound 4; then compounds 3, 1 and 2 (each within the scatter of the next).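

In this assay, methylcarbamoyl in place of (methanesulfonamido)methyl gives a 2.4-fold lower number from compound 1 to compound 4 (0.38 log units; beyond the scatter), a modest step but beyond the scatter. The earlier step at this place, a 1.7-fold lower number from compound 2 to compound 3 (0.24 log units; within the scatter), stayed within the scatter, so the side-chain end can move the number when the rest of compound 1 is held fixed. Nothing available explains this step.

The change alters both the end group and the chain, and these two remain unseparated. Also open, going by these compounds, is how a longer chain ending in methylcarbamoyl, or a carboxylic acid at this place, would read.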